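The source may hold more compounds than are shown below. What is called first, only, known or untested is meant among the compounds shown, and "the series" means these compounds.

Compound 1, `O=C(CSc1nnnn1-c1cccc2ccccc12)N/N=C/c1cccs1`: in an ADME assay on MT4 cells (Homo sapiens) for cytotoxicity, read by MTT assay (a lower number here means that less compound is tolerated, a higher number that more compound is tolerated), compound 1 gives > 316000 nM, a limit of the assay.
Compound 2, `O=C(CSc1nnnn1-c1cccc2ccccc12)N/N=C/c1ccc(F)cc1`: in this assay compound 2 gives > 307000 nM, again a limit.
Compound 3, `COc1ccc(/C=N/NC(=O)CSc2nnnn2-c2cccc3ccccc23)cc1`: compound 3 gives > 298000 nM, also a limit.

Compound 3 thus sits at a limit (the limit of > 298000 nM in this assay, at which 1 of the 3 values shown sits), as do the other two the limit of > 307000 nM in this assay, at which 1 of the 3 values shown sits (the limit of > 316000 nM in this assay, at which 1 of the 3 values shown sits), and the three steps a step that the two limits leave unreadable from compound 1 to compound 2, a step that the two limits leave unreadable from compound 1 to compound 3 and a step that the two limits leave unreadable from compound 2 to compound 3 cannot be read. The unmeasured compound 4, `COc1ccc(O)c(/C=N/NC(=O)CSc2nnnn2-c2cccc3ccccc23)c1`, differs by 2-hydroxy-5-methoxyphenyl in place of 4-methoxyphenyl on a carbon with a double bond to nitrogen. The step that the two limits leave unreadable from compound 2 to compound 3 concerns the same ring but tells no size. No step beyond the scatter is therefore expected, and compound 4 is estimated at 300000 nM, within 150000 nM to 600000 nM, the expected step from compound 3 being a step that the limit leaves unreadable from compound 3 to compound 4.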

Compound 4, half-maximal cytotoxic concentration: 4510 nM
Estimate against measurement, compound 4: 67-fold (1.82 log units) above; the whole stated range lies above it.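

At this position the group on the carbon with a double bond to nitrogen can clearly matter in this assay: 2-hydroxy-5-methoxyphenyl gives an at least 66-fold lower number from compound 3 to compound 4 (1.82 log units; beyond the scatter), an at least 68-fold lower number from compound 2 to compound 4 (1.83 log units; beyond the scatter) and an at least 70-fold lower number from compound 1 to compound 4 (1.84 log units; beyond the scatter). Compound 1, compound 2 and compound 3 all stand at limits, so the steps among them cannot be read and gave no sign of this. Nothing measured here gives a reason for this drop. As far as these compounds go, whether the hydroxy group alone carries the step stays open, as does the outcome with 2-hydroxyphenyl, or with an amine or a carboxylic acid in place of the hydroxy group.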